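The source may hold more compounds than are shown below. What is called first, only, known or untested is meant among the compounds shown, and "the series" means these compounds.

Two compounds of the series have numbers in a functional assay on CAKI-1 cells (Homo sapiens) for inhibition, read by sulforhodamine B assay, with a stated time of 48 h; on this read-out higher numbers stand for weaker inhibition of growth and lower numbers for stronger inhibition of growth. Compound 1 `COc1cc(C(=O)/C=C/c2c(-c3cccs3)nc3ccccn23)cc(OC)c1OC` gives 2310 nM there. Compound 2 `COc1cc(C(=O)/C=C/c2c(-c3ccc(F)cc3)nc3ncccn23)cc(OC)c1OC` gives 2060 nM in this assay, the lower of the two figures, though the gap to compound 1 lies within the scatter, so no order between them is read. Compound 3 `COc1ccc(-c2nc3ncccn3c2/C=C/C(=O)c2cc(OC)c(OC)c(OC)c2)cc1` is not yet measured. It differs from compound 2 by methoxy in place of fluoro on an aromatic carbon, on an aromatic carbon of a six-membered aromatic ring of carbon only, para to a large group. Among the measured compounds shown here, no measured step of this kind is available. The change is expected to stay within the scatter, a 1.1-fold lower number from compound 2 to compound 3 (0.06 log units; within the scatter). Compound 3 is therefore estimated at 1800 nM in this assay, with a range from 700 nM to 5000 nM.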

Compound 3, concentration for 50% growth inhibition: 1580 nM
Compound 3: the middle estimate sits 1.1-fold (0.06 log units) above what was measured, and the stated range covers the measured number.
By their numbers in this assay, from the lowest: compounds 3, 2 and 1 (each within the scatter of the next).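

Working from the listed step, methoxy in place of fluoro on an aromatic carbon gives in this assay a 1.3-fold lower number from compound 2 to compound 3 (0.12 log units; within the scatter), the first single-place comparison in the series. At this position, para to a large group, 4-fluorophenyl and 4-methoxyphenyl are therefore not separated by this read-out, although the entering group adds a heavy atom and a hydrogen-bond acceptor. Nothing available bears on a cause for this result.

From the compounds shown here alone, whether an amine or a carboxylic acid at this position would give a step beyond the scatter remains open. A longer chain, such as butoxy, is equally unresolved, and one step cannot show how far the position tolerates change.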